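The source may report more compounds than this note shows. Statements on the series, on what has been measured and on what is new or still open speak of the compounds shown alone.

Measured compounds:
compound 1, `Cc1nc(COc2ccc(/C=C3\SC(=O)NC3=O)cc2)cs1`, gives 18.6%
compound 2, `COc1ccc(-c2nnc(SCCOc3ccc(/C=C4\SC(=O)NC4=O)cc3)[nH]2)cc1`, gives 43.1%
compound 3, `O=C1NC(=O)/C(=C/c2ccc(OCCSc3nnc(-c4ccccc4)o3)cc2)S1`, gives 21.6%

All three values come from a functional assay on the whole organism (strain Wistar) with Rattus norvegicus as the target, with a stated time of 15 days, at a dose of 3 mg/kg by the oral route; on this read-out higher numbers stand for a stronger effect at the one dose given and lower numbers for a weaker effect. Compound 3 stands second highest of the three numbers. Its nearest neighbour is compound 1, whose value in this assay is lower than that of compound 3 by a gap within the scatter, so no order between these two can be read from the data. Compound 2 lies furthest away, with a number beyond the scatter above compound 3.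

Compound 4, `O=C1NC(=O)/C(=C/c2ccc(OCCSc3nnc(-c4cccnc4)o3)cc2)S1`, is the next compound to be measured. It differs from compound 3 in one place: pyridin-3-yl in place of phenyl on an aromatic carbon. Going by the values given here, no pair of measured compounds differs in a single place, so no measured step of this kind exists for comparison. The change is small in size and leaves the rest of the molecule untouched, so in this assay no step beyond the scatter is expected, with the direction open.

Compound 4 is therefore expected to give 24%, in a range from 10% to 42%. This estimate means a step of a number 2.4 percentage points higher from compound 3 to compound 4 (within the scatter), which is expected to stay within the scatter.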

Compound 4, a percentage reported as activity, at one dose (the size of the read-out at that dose, not a potency): 40.7%
Compound 4: the middle estimate sits 16.7 percentage points below what was measured, within the range that was stated.
By their numbers in this assay, from the lowest: compounds 1 and 3 (each within the scatter of the next); then compounds 4 and 2 (each within the scatter of the next).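

In this assay, going by these compounds alone, the first single-place change, pyridin-3-yl in place of phenyl on the aromatic carbon of the five-membered aromatic ring with 2 nitrogen and 1 oxygen, gives a number 19.1 percentage points higher from compound 3 to compound 4 (beyond the scatter). This position is therefore not indifferent to a small exchange: both groups have 6 heavy atoms and one six-membered aromatic ring, and the counted differences are a ring nitrogen in place of a ring carbon and 1 hydrogen-bond acceptor where phenyl has 0. No measurement shown here explains the step, so it stands as an observation without an assigned cause.

The compounds shown leave open whether the step depends on having a ring nitrogen at all or on where that nitrogen sits in the ring, a question that pyridin-2-yl and pyridin-4-yl on the same carbon would address. As far as these compounds go, it also remains open whether a pyrimidin-5-yl ring, or a phenyl ring bearing an amine or a carboxylic acid, would give a similar step at this one dose.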